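Compound 2 to compound 4: a ring swap on the side chain

The compounds below may be only part of what the source reports. "The series", "measured", "known", "first", "only" and "open" are said of these compounds alone.

In a functional assay on MGC-803 cells (Homo sapiens) for cytotoxicity, read by MTT assay, with a stated time of 38 h (on this read-out lower numbers stand for stronger inhibition and higher numbers for weaker inhibition), compound 2 `COc1cc(OC)c2c(=O)c(OCC(=O)N/N=C/c3ccc[nH]3)c(-c3cc(OC)c(OC)c(OC)c3)oc2c1` gives 5610 nM and compound 3 `COc1cc(OC)c2c(=O)c(OCC(=O)N/N=C/c3ccco3)c(-c3cc(OC)c(OC)c(OC)c3)oc2c1` gives 6050 nM on the same core. The step of a 1.1-fold higher number from compound 2 to compound 3 (0.03 log units; within the scatter) lies within the scatter, so these two share the low end of the three numbers. Compound 1 `COc1cc(OC)c2c(=O)c(OCCCCN3CCCCC3)c(-c3cc(OC)c(OC)c(OC)c3)oc2c1` gives 26800 nM and stands apart from both.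

The next compound, compound 4 `COc1cc(OC)c2c(=O)c(OCC(=O)N/N=C/c3ccccn3)c(-c3cc(OC)c(OC)c(OC)c3)oc2c1`, differs from compound 2 by pyridin-2-yl in place of 1H-pyrrol-2-yl on a carbon with a double bond to nitrogen in the form of pyridin-2-yl in place of 1H-pyrrol-2-yl on a carbon with a double bond to nitrogen.

The closest guide is compound 3, where furan-2-yl at this same place gave a 1.1-fold higher number from compound 2 to compound 3 (0.03 log units; within the scatter) and so no change beyond the scatter. The other two steps, a 4.8-fold lower number from compound 1 to compound 2 (0.68 log units; beyond the scatter) and a 4.4-fold lower number from compound 1 to compound 3 (0.65 log units; beyond the scatter), are modest and lie beyond the scatter, but they replace the whole end of the side chain and say little about a swap of one aromatic ring. No six-membered aromatic ring has been measured at this place, so the range stays wide.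

No step beyond the scatter is expected in this assay, the estimated step being a 1.0-fold lower number from compound 2 to compound 4 (0.01 log units; within the scatter) with either direction open. For compound 4 an estimated 5500 nM is expected, within a range of 2300 nM to 12000 nM on this read-out.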

Compound 4, half-maximal inhibitory concentration: 15300 nM
Compound 4: middle estimate off by 2.8-fold (0.44 log units), on the low side, outside the stated range (above it).
By their numbers in this assay, from the lowest: compounds 2 and 3 (each within the scatter of the next); then compounds 4 and 1 (each within the scatter of the next).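

Working notes on the ring at the end of the side chain: in this assay, the ring on the carbon with a double bond to nitrogen does matter, although the two five-membered aromatic rings had given no step beyond the scatter. Pyridin-2-yl shifts the number beyond the scatter against both of them (a 2.7-fold higher number from compound 2 to compound 4 (0.44 log units; beyond the scatter); a 2.5-fold higher number from compound 3 to compound 4 (0.40 log units; beyond the scatter)). The advantage that compound 2 and compound 3 showed over compound 1 is not retained with this six-membered aromatic ring, as the step from the piperidine-ended chain stays within the scatter (a 1.8-fold lower number from compound 1 to compound 4 (0.24 log units; within the scatter)), and nothing available here bears on the reason for the shift.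

Still open, from the compounds shown here alone, is whether the step follows ring size or the particular ring: phenyl, pyridin-3-yl or pyridin-4-yl at this place would separate those two readings. Going by these compounds, it is equally open how a five-membered aromatic ring with two hetero atoms, such as imidazol-2-yl or thiazol-2-yl, would compare with the 1H-pyrrol-2-yl and furan-2-yl pair.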